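Aryl swap on a carbamate nitrogen, low starting point

The compounds below may be only part of what the source reports. "The series", "measured", "known", "first", "only" and "open" are said of these compounds alone.

In a functional assay on PANC-1 cells (Homo sapiens) for inhibition, read by MTT assay, with a stated time of 24 h, tested at 10 uM (a higher number here means more inhibition at the concentration tested (going by the name of the read-out), a lower number less inhibition), three compounds of one family have been measured. Compound 1 `CC(C)=CCC1Cc2c(OCCCNS(=O)(=O)c3ccc(C(F)(F)F)cc3)cc(=O)n(CCCO)c2CC1(C)C` gives 29.6%, and compound 2 `CC(C)=CCC1Cc2c(OCCCNS(=O)(=O)c3ccc(Cl)cc3)cc(=O)n(CCCO)c2CC1(C)C` gives 24.7%. Among the measured compounds shown here, the step of a number 4.9 percentage points lower from compound 1 to compound 2 (within the scatter) is the only single-change step among the measured compounds. Compound 3 `COc1ccc(NC(=O)Oc2cc(=O)n(CCCO)c3c2CC(CC=C(C)C)C(C)(C)C3)cc1` differs from both in more than one place and gives 3.7%, the lowest of the three values, clearly apart from both compound 1 and compound 2. Compound 4 `CC(C)=CCC1Cc2c(OC(=O)Nc3ccc(F)c(Cl)c3)cc(=O)n(CCCO)c2CC1(C)C` keeps everything of compound 3 except the aryl group on the nitrogen: 3-chloro-4-fluorophenyl in place of 4-methoxyphenyl on an amide-type nitrogen. For the measured compounds named here, no measured step touches this position. The step from compound 1 to compound 2 exchanged one small aryl substituent for another and stayed within the scatter, which offers only a loose hint that such exchanges move this read-out little. Compound 4 is therefore expected to remain near compound 3, with a number 6.3 percentage points higher from compound 3 to compound 4 (within the scatter) as the estimated step. The estimate for compound 4 is 10%, ranging from -5% to 25%.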

Compound 4, a percentage reported as inhibition, at one concentration (the size of the read-out at that concentration, not a potency): 79.8%
Compound 4: middle estimate off by 69.8 percentage points, on the low side; the whole stated range lies below it.
By their numbers in this assay, from the lowest: compound 3; then compounds 2 and 1 (each within the scatter of the next); then compound 4.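

The aryl group on the amide-type nitrogen turns out to be a highly sensitive spot: in this assay, replacing 4-methoxyphenyl with 3-chloro-4-fluorophenyl gives a number 76.1 percentage points higher from compound 3 to compound 4 (beyond the scatter). The two groups have the same heavy-atom count and the same six-membered aromatic ring of carbon, so a change of ring substituents alone separates a low reading from a high one. No accompanying measurement bears on why this step is so large.

The chlorine, the fluorine and the loss of the methoxy group all changed together, and the compounds shown do not separate their shares of the step. Also open, from the compounds shown here alone, is how this nitrogen would behave carrying a plain phenyl, a pyridyl group, or an aryl ring with only chlorine or only fluorine.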